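Hydroxamic acid series: carboxy for hydroxymethyl on the saturated ring

The compounds below may be only part of what the source reports. "The series", "measured", "known", "first", "only" and "open" are said of these compounds alone.

Measured so far:
compound 1 `O=C(/C=C/c1cn([C@H]2C[C@@H](CO)N(CCCc3ccccc3)C2)nn1)NO` — 31%
compound 2 `O=C(/C=C/c1cn([C@H]2C[C@H](CO)N(CCCc3ccccc3)C2)nn1)NO` — 16%

Going by the values given here, in an assay on Sf9 cells for inhibition of histone deacetylase 11 (Homo sapiens), read by fluorescence, tested at 0.5 uM (on this read-out lower numbers stand for less inhibition and higher numbers for more inhibition at the one concentration tested (going by the name of the read-out)), compound 2 gives 16%, the lower of the two numbers recorded; the only other compound, compound 1, gives 31% in this assay. Among the compounds with values here, the single measured step, a number 15 percentage points lower from compound 1 to compound 2 (beyond the scatter), turns on configuration alone the fact that compounds 1 and 2 differ only in the configuration as drawn and leaves every group in place.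

Compound 3 `O=C(/C=C/c1cn([C@H]2C[C@H](C(=O)O)N(CCCc3ccccc3)C2)nn1)NO` is not yet measured. It differs from compound 2 by carboxy in place of hydroxymethyl on a saturated ring carbon. Within the data shown here, no measured step in this assay involves an exchange of this kind, so the only guidance is the low starting point of compound 2 and the direct comparison between the two measured compounds. On that basis a step of no more than the usual scatter is expected, a number 3 percentage points lower from compound 2 to compound 3 (within the scatter), with the number staying low. The estimate for compound 3 in this assay is 13%, expected to fall between 0% and 30%.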

Compound 3, a percentage reported as inhibition, at one concentration (the size of the read-out at that concentration, not a potency): 20%
The estimate for compound 3 lay 7 percentage points below the measured number; low and high end bracket the measured number.
By their numbers in this assay, from the lowest: compounds 2 and 3 (each within the scatter of the next); then compound 1.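

In this assay, carboxy in place of hydroxymethyl on the saturated ring carbon next to the ring nitrogen gives a number 4 percentage points higher from compound 2 to compound 3 (within the scatter). With the configuration of compound 2 held, the group at this carbon can therefore be exchanged without a step beyond the scatter, whereas the earlier pair showed only the effect of configuration, a number 15 percentage points lower from compound 1 to compound 2 (beyond the scatter). Nothing in the data shown accounts for this outcome.

Open, on these data alone, is whether carboxy gives a similar reading in this assay on the configuration drawn in compound 1, where the hydroxymethyl compound stands higher. Also open, as far as these compounds go, is how a primary carboxamide, a methyl ester or an aminomethyl group at this ring carbon would read.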